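This account rests on a few compounds, and the source may have more. Where it says the series, first, only, none or still open, it means among the compounds named here.

Compound 1 `COc1cc2oc(-c3cccc(NC(=O)c4ccc(F)cc4)c3)cc(=O)c2c(OC)c1OC` belongs to a small set of compounds that share one core and differ only in the group attached to the amide carbonyl. In a functional assay on UO-31 cells (Homo sapiens) for inhibition, read by sulforhodamine B assay, tested at 10 uM (a lower number here means less inhibition, a higher number more inhibition at the concentration tested (going by the name of the read-out)), compound 1 is reported as "active" (no number reported), so no single number marks where it stands. Two close relatives do carry numbers: compound 2 `COc1cc2oc(-c3cccc(NC(=O)c4ccc(Cl)cc4)c3)cc(=O)c2c(OC)c1OC` gives 51.1% in this assay, and compound 3 `COc1cc2oc(-c3cccc(NC(=O)c4ccc(Br)cc4)c3)cc(=O)c2c(OC)c1OC` gives 63.6%. Going by the values given here, the one step between measured compounds, a number 12.5 percentage points higher from compound 2 to compound 3 (beyond the scatter), concerns bromo in place of chloro on an aromatic carbon, which is a different kind of change from the one followed here.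

Compound 4 `COc1cc2oc(-c3cccc(NC(=O)c4cccc(C#N)c4)c3)cc(=O)c2c(OC)c1OC` arises from compound 1 through (3-cyanophenyl in place of 4-fluorophenyl on a carbonyl carbon). Among the compounds with values here, no measured step covers this exchange, so the expectation rests only on the range spanned by compounds 2 and 3, since compound 1 carries a reported verdict but no number. Compound 4 is therefore estimated to give about 50% in this assay, with a plausible spread from 25% to 75%.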

Compound 4, a percentage reported as inhibition, at one concentration (the size of the read-out at that concentration, not a potency): "active" (no number reported)
The entry for compound 4 holds no number; the estimate stays without a comparison.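

In this assay compound 1 gives "active" (no number reported) and compound 4 gives "active" (no number reported), so no step can be read between them. The compounds shown leave open how much 3-cyanophenyl in place of 4-fluorophenyl changes inhibition. No other data bear on this result.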